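The source may report more compounds than this note shows. Statements on the series, on what has been measured and on what is new or still open speak of the compounds shown alone.

- Compound 1 `Fc1ccc(-c2ccc(-c3ccc(-c4nc5ccccc5[nH]4)cc3)cc2)cc1`: 41200 nM
- Compound 2 `FC(F)(F)Oc1ccc(-c2ccc(-c3ccc(-c4nc5ccccc5[nH]4)cc3)cc2)cc1`: 100000 nM
- Compound 3 `COc1ccc(-c2ccc(-c3ccc(-c4nc5ccccc5[nH]4)cc3)cc2)cc1`: 100000 nM

These values come from a functional assay on PC-3 cells (Homo sapiens) for inhibition, read by sulforhodamine B assay; a higher number here means a weaker inhibitor of growth, a lower number a stronger inhibitor of growth. Compound 3 stands level with compound 2, and the number for compound 1 lies lower than both.

Compound 4 `CN(C)c1ccc(-c2ccc(-c3ccc(-c4nc5ccccc5[nH]4)cc3)cc2)cc1` differs from compound 3 by one change, (dimethylamino in place of methoxy on an aromatic carbon), with dimethylamino in place of methoxy on an aromatic carbon, para to a large group.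

All three measured steps alter the group at this place. The step of a 2.4-fold higher number from compound 1 to compound 3 (0.39 log units; beyond the scatter) and the step of a 2.4-fold higher number from compound 1 to compound 2 (0.39 log units; beyond the scatter) are modest, while the step of no change at the digits printed from compound 2 to compound 3 (within the scatter) lies within the scatter. Going by the values given here, none of them involves dimethylamino, so the data offer no direct precedent. A modest step is therefore the most that is expected in this assay, leaning towards a lower number, since compound 3 already gives 100000 nM, level with the highest value seen so far.

The expected change is a 1.4-fold lower number from compound 3 to compound 4 (0.15 log units; within the scatter). For compound 4 the estimated value is 70000 nM, within an expected range from 30000 nM to 100000 nM.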

Compound 4, concentration for 50% growth inhibition: 100000 nM
Compound 4: middle estimate off by 1.4-fold (0.15 log units), on the low side; measured number inside the range.
By their numbers in this assay, from the lowest: compound 1; then compounds 2, 3 and 4 (each within the scatter of the next).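

In this assay, putting dimethylamino on this aromatic carbon, para to a large group, gives no change at the digits printed from compound 3 to compound 4 (within the scatter), and replacing trifluoromethoxy with it gives no change at the digits printed from compound 2 to compound 4 (within the scatter), so a nitrogen-linked group now joins the two oxygen-linked ones and the assay does not tell the three apart. Fluoro remains the only group at this place that stands apart, with a 2.4-fold higher number from compound 1 to compound 4 (0.39 log units; beyond the scatter), which makes compound 1 the one departure from an otherwise flat set of four. Nothing measured here accounts for this flat result or for the place of compound 1.

The compounds shown leave open whether the lower number of compound 1 is particular to fluoro or would also appear with chloro or with plain hydrogen at this place. They also leave open how a carboxylic acid or a primary amine here would read.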